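Tetrazole Nitrogen Substituent Swap in Tolerance on Vero Cells

A few compounds are considered here, and "the series" means these few. Any claim that something is new, unique, unknown or untested is made for them only; others in the source may bear on it.

Compound 1 `COc1ccc(C(Nc2ccc(C3(C)NC(=O)c4ccccc4N3)cc2)c2nnnn2C2CCCCC2)cc1` carries a cyclohexyl group on the tetrazole nitrogen. In an ADME assay on Vero cells (Chlorocebus sabaeus) for cytotoxicity, read by MTT assay, with a stated time of 72 h (a lower number here means that less compound is tolerated, a higher number that more compound is tolerated), compound 1 gives "not determined" (no result reported), so no number stands for it. Its companion compound 2 `CC1(c2ccc(NC(c3ccc(Cl)cc3)c3nnnn3C3CCCCC3)cc2)NC(=O)c2ccccc2N1` differs in the aryl substituent. In this assay compound 2 reaches only > 400000 nM, which is a limit of the assay rather than a number; this is the limit of > 400000 nM in this assay, at which 1 of the 2 values shown sits. Compound 3 `COc1ccc(C(Nc2ccc(C3(C)NC(=O)c4ccccc4N3)cc2)c2nnnn2C(C)(C)C)cc1` is yet to be measured. It differs from compound 1 by tert-butyl in place of cyclohexyl on an aromatic nitrogen. Among the measured compounds shown here, with no measured step to build on, the change is expected to shift tolerance in this assay by no more than the usual scatter, in either direction. Compound 3 is therefore estimated at 400000 nM in this assay, within a range from 150000 nM to 1000000 nM, with a fair chance that only a limit is reported.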

Compound 3, half-maximal cytotoxic concentration: > 400000 nM
Compound 3 was reported as a limit; the forecaster's own chance of this, stated with the estimate: 65%; the middle value lies on the limit itself.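

No step from compound 1 to compound 3 can be read, since compound 1 stands without a number and compound 3 gives only a limit in this assay: the limit of > 400000 nM in this assay, at which 2 of the 3 values shown sit.

The compounds shown leave open whether tert-butyl in place of cyclohexyl changes tolerance in this assay at all.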